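Selenium to sulfur on a shared isothiourea-type linker

The compounds below may be only part of what the source reports. "The series", "measured", "known", "first", "only" and "open" are said of these compounds alone.

Of the compounds shown here, two have been measured in a functional assay on K562 cells (Homo sapiens) for cytotoxicity, read by MTT assay, with a stated time of 72 h; a lower number here means a stronger inhibitor of growth, a higher number a weaker inhibitor of growth. Compound 1 `CS/C(=N\C(=O)c1cc2ccccc2s1)NC(=O)c1cc2ccccc2s1` gives 66600 nM in this assay. Compound 2 `C[Se]/C(=N\C(=O)c1cnc2ccccc2c1)NC(=O)c1cnc2ccccc2c1` gives 29900 nM in this assay, the lower of the two numbers, and the step from compound 2 up to compound 1 lies beyond the scatter. The two differ in more than one place, so no single change can be tied to that gap.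

Compound 3 `CS/C(=N\C(=O)c1cnc2ccccc2c1)NC(=O)c1cnc2ccccc2c1` is not yet measured. It differs from compound 2 in one place: a group of 2 heavy atoms (1 carbon, 1 sulfur; no ring) in place of a group of 2 heavy atoms (1 carbon, 1 selenium; no ring), on a carbon with a double bond to nitrogen. Going by the values given here, with no measured pair that isolates this change, the expectation rests on compound 2 alone; the step from compound 2 to compound 3 is expected to be small, a 1.5-fold higher number from compound 2 to compound 3 (0.18 log units; within the scatter), with a weaker inhibition of growth somewhat more likely than a stronger one. Compound 3 is therefore estimated at 45000 nM in this assay, within a range of 20000 nM to 110000 nM.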

Compound 3, concentration for total growth inhibition: > 100000 nM
Compound 3 was reported as a limit; the forecaster's own chance of this, stated with the estimate: 10%; at least 2.2-fold (0.34 log units) between middle value and limit.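

In this assay, methylsulfanyl in place of the group of one carbon and one selenium, on a carbon with a double bond to nitrogen, gives an at least 3.3-fold higher number from compound 2 to compound 3 (0.52 log units; beyond the scatter). Going by these compounds alone, this is the first change here isolated in one place, and it shows that the selenium-containing group goes with stronger inhibition of growth on this core, by a margin beyond the scatter. Compound 3 gives > 100000 nM, which is a limit and not a number, so the full size of the step cannot be read because the value stands at that limit: the limit of > 100000 nM in this assay, at which 1 of the 3 values shown sits.

From the compounds shown here alone, whether the same exchange moves the number in the same direction on the core of compound 1 remains open. Also open, going by these compounds, is whether a longer chain on the selenium, or an amine in this place, would keep the inhibition of growth seen with compound 2.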